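The source may hold more compounds than are shown below. What is called first, only, known or untested is meant among the compounds shown, and "the series" means these compounds.

Compound 1 `FC(F)(F)c1ccc(-c2ccc(-c3ccc(-c4nc5ccccc5[nH]4)cc3)cc2)cc1` and compound 2 `FC(F)(F)Oc1ccc(-c2ccc(-c3ccc(-c4nc5ccccc5[nH]4)cc3)cc2)cc1` share one core and differ in a single spot: trifluoromethoxy in place of trifluoromethyl on an aromatic carbon. In a functional assay on DWD cells (Homo sapiens) for inhibition, read by sulforhodamine B assay (a lower number here means a stronger inhibitor of growth, a higher number a weaker inhibitor of growth), compound 1 gives 100000 nM, and compound 2 gives 100000 nM, so that change made no change at the digits printed from compound 1 to compound 2 (within the scatter). Compound 3 `Cc1ccc2[nH]c(-c3ccc(-c4ccc(-c5ccc(C(F)(F)F)cc5)cc4)cc3)nc2c1` carries a different core, and its difference from compound 1 is methyl in place of hydrogen on an aromatic carbon; in this assay compound 3 gives 38200 nM, which is a 2.6-fold lower number from compound 1 to compound 3 (0.42 log units; beyond the scatter). Compound 4 `Cc1ccc2[nH]c(-c3ccc(-c4ccc(-c5ccc(OC(F)(F)F)cc5)cc4)cc3)nc2c1` has not yet been tested. It differs from compound 3 by trifluoromethoxy in place of trifluoromethyl on an aromatic carbon, the same change seen between compound 1 and compound 2, at a place described in the same words. Because that earlier change gave no change at the digits printed from compound 1 to compound 2 (within the scatter), the step from compound 3 to compound 4 in this assay is expected to be a 1.0-fold higher number from compound 3 to compound 4 (0.02 log units; within the scatter). For compound 4 the expected value in this assay is therefore 40000 nM, between 15000 nM and 100000 nM.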

Compound 4, concentration for 50% growth inhibition: 41100 nM
Estimate against measurement, compound 4: 1.0-fold (0.01 log units) below; measured number inside the range.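

In this assay the change from trifluoromethyl to trifluoromethoxy gave a 1.1-fold higher number from compound 3 to compound 4 (0.03 log units; within the scatter) and so behaved on the methyl-bearing core as it did on the core of compound 1: the same change on two cores in this assay, no change at the digits printed (within the scatter) from compound 1 to compound 2 and a 1.1-fold higher number (0.03 log units; within the scatter) from compound 3 to compound 4, 1.1-fold (0.03 log units) apart, within the scatter of two such steps. The methyl carried over in the same way, giving a 2.4-fold lower number from compound 2 to compound 4 (0.39 log units; beyond the scatter) with trifluoromethoxy in place, much as it did with trifluoromethyl: the same change on two cores in this assay, a 2.6-fold lower number (0.42 log units; beyond the scatter) from compound 1 to compound 3 and a 2.4-fold lower number (0.39 log units; beyond the scatter) from compound 2 to compound 4, 1.1-fold (0.03 log units) apart, within the scatter of two such steps. Within these four compounds the two changes act independently of each other, but two pairs per change cannot show that this holds on other cores, nor explain why it holds here.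

The compounds shown leave open whether an amine or a carboxylic acid in place of trifluoromethyl would give a clearly lower number in this assay and whether a longer chain in place of the methyl would extend the step seen with methyl.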